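Phenoxy in place of methoxyethoxy on a triazine anilide

The compounds below may be only part of what the source reports. "The series", "measured", "known", "first", "only" and "open" are said of these compounds alone.

Compound 1 `C=CC(=O)Nc1cccc(Nc2nc(Cl)nc(Nc3ccc(OCCOC)cc3)n2)c1`: "not determined" (no result reported)
Compound 2 `C=CC(=O)Nc1cccc(Nc2ncnc(Nc3ccc(C(=O)Nc4ccccn4)cc3)n2)c1`: 15600 nM
Compound 3 `CC#CC(=O)Nc1cccc(Nc2ncnc(Nc3ccc(C(=O)N4CCCCC4)cc3)n2)c1`: 4620 nM

In a functional assay on Raji cells (Homo sapiens) for antiproliferative activity, read by CCK-8 assay, with a stated time of 24 h (a lower number here means a stronger inhibitor, a higher number a weaker inhibitor), compound 1 is recorded as "not determined" (no result reported), so no number anchors it. Compound 2 gives 15600 nM in this assay, and compound 3 gives 4620 nM. Compound 4 `C=CC(=O)Nc1cccc(Nc2nc(Cl)nc(Nc3ccc(Oc4ccccc4)cc3)n2)c1` differs from compound 1 by phenyl in place of 2-methoxyethyl on an oxygen on an aromatic ring. For the measured compounds named here, no measured pair shows this change, and compound 1 itself carries no value, so the size and direction of the step in this assay cannot be read from the data; nothing beyond the scatter is expected with confidence in either direction. With compound 2 at 15600 nM and compound 3 at 4620 nM as the only points of reference, compound 4 is expected to fall in the same micromolar region. Compound 4 is estimated at 6000 nM, within a range from 1200 nM to 30000 nM.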

Compound 4, half-maximal inhibitory concentration: 15700 nM
Beside the measured number, compound 4's estimate is 2.6-fold (0.42 log units) below it; measured number inside the range.
By their numbers in this assay, from the lowest: compound 3; then compounds 2 and 4 (each within the scatter of the next).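

For the compounds shown here, no step from compound 1 to compound 4 can be read in this assay, and nothing offered here bears on the result. The compounds shown leave open how 2-methoxyethoxy to phenoxy alters activity in this assay on this core.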